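The compounds below may be only part of what the source reports. "The series", "measured", "known", "first", "only" and "open" are said of these compounds alone.

Of the compounds shown here, two sharing one core have so far been tested in an ADME assay on the whole organism for cytotoxicity, with Artemia salina as the target; a higher number here means a weaker inhibitor, a lower number a stronger inhibitor. Compound 1, `CCCCCCCC(C)CCC/C(O)=C1\C(=O)C(C)N(C)C1=O`, gives in this assay 36.6 ug/mL. Compound 2, `CCCCCCCCCCCCC/C(O)=C1\C(=O)CN(C)C1=O`, gives in this assay 48.8 ug/mL. These two numbers lie within the usual scatter of each other, so on the numbers shown neither compound can be called the stronger or the weaker inhibitor; compound 2 simply stands alongside compound 1.

Compound 3, `CCC(C)CCCCCCCCCC/C(O)=C1\C(=O)CN(C)C1=O`, has not yet been measured. It differs from compound 2 in one place: methyl in place of hydrogen on a saturated chain carbon bound to two saturated chain carbons. Among the compounds with values here, no step between measured compounds isolates this change. The only hint comes from the measured pair: compound 2 gives 48.8 ug/mL, and compound 1, which among other differences also carries a methyl on a saturated chain carbon, gives 36.6 ug/mL, within the scatter. That gives no sign that a chain methyl by itself moves the number. The step from compound 2 to compound 3 in this assay is therefore expected to be a 1.2-fold lower number from compound 2 to compound 3 (0.07 log units; within the scatter), not beyond the scatter. Compound 3 is estimated at 42 ug/mL, with a range from 20 ug/mL to 90 ug/mL.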

Compound 3, half-maximal inhibitory concentration: 52.6 ug/mL
Estimate against measurement, compound 3: 1.3-fold (0.10 log units) below; the range from low to high includes it.
By their numbers in this assay, from the lowest: compounds 1, 2 and 3 (each within the scatter of the next).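

Within the data shown here, until now, no step between measured compounds isolated this change; this pair does. In this assay, methyl in place of hydrogen on a saturated chain carbon bound to two saturated chain carbons gives a 1.1-fold higher number from compound 2 to compound 3 (0.03 log units; within the scatter), and that step lies within the scatter, so at this position on the chain, the added methyl leaves no measurable mark on the number. No measured information on the compounds is available to explain this result.

On these data alone, a single step speaks for only one position and one small group, so it remains open whether a methyl elsewhere on the chain would likewise stay within the scatter, or whether a different group at this same carbon, such as a hydroxyl, an amine or a carboxylic acid, would move the number beyond it. Among these compounds, also open is how a much shorter or longer chain on the shared core would read in this assay, since the chains of compound 2 and compound 3 offer no step that tests chain length alone.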